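Swapping the sulfonamide substituent of compound 1 for cyclopropyl

This account rests on a few compounds, and the source may have more. Where it says the series, first, only, none or still open, it means among the compounds named here.

Of the compounds shown here, three that share one core have been tested in a functional assay on OVCAR-3 cells (Homo sapiens) for activation, with a stated time of 24 h; a higher number here means that more compound is needed for the effect, a lower number that less compound is needed. Compound 1, `CC(C)(C)NS(=O)(=O)c1cccc(NC(=O)c2cccnc2N2CCC3(CC2)CC3)c1`, gives 1030 nM. Compound 2, `COc1ccc(C(=O)Nc2cccc(S(=O)(=O)C3CCCC3)n2)c(N2CCC3(CC2)CC3)c1`, gives 2660 nM, and compound 3, `CC(C)(O)CNc1ccc(C(=O)Nc2cccc(S(=O)(=O)C3CCCC3)n2)c(N2CCC3(CC2)CC3)c1`, gives 228 nM. Compound 1 therefore stands second highest of the three numbers: compound 2 lies above it and compound 3 lies below it, and both gaps are beyond the usual scatter. Going by the values given here, the only single change among the measured compounds is a 12-fold lower number from compound 2 to compound 3 (1.07 log units; beyond the scatter), a large step, but it concerns a substituent on an aromatic carbon that compound 1 does not carry.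

Compound 4, `O=C(Nc1cccc(S(=O)(=O)NC2CC2)c1)c1cccnc1N1CCC2(CC1)CC2`, has not yet been measured in this assay. It differs from compound 1 in one place: cyclopropyl in place of tert-butyl on a sulfonamide nitrogen. Among the compounds with values here, no measured pair shows this particular exchange, and the change from compound 2 to compound 3 sits elsewhere on the core, so it gives no direct guide. With nothing in the data pointing either way, the expectation is a step that stays within the scatter, a 1.0-fold lower number from compound 1 to compound 4 (0.01 log units; within the scatter), with the range kept wide. Compound 4 is thus estimated at 1000 nM, between 350 nM and 3000 nM.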

Compound 4, half-maximal effective concentration: 2260 nM
Beside the measured number, compound 4's estimate is 2.3-fold (0.35 log units) below it; measured number inside the range.
By their numbers in this assay, from the lowest: compound 3; then compound 1; then compounds 4 and 2 (each within the scatter of the next).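

The sulfonamide nitrogen is not a silent position in this assay: cyclopropyl in place of tert-butyl gives a 2.2-fold higher number from compound 1 to compound 4 (0.34 log units; beyond the scatter) and so moves the number by a modest step that is still beyond the scatter. The exchange itself is small, going from tert-butyl with 4 heavy atoms and no ring to cyclopropyl with 3 heavy atoms and one three-membered ring, and neither group adds a hydrogen-bond donor or acceptor, yet even this much can be read in the result. No measurement here explains the step, so the data show only that it happens, not what lies behind it.

From the compounds shown here alone, how the number responds to other groups on this nitrogen remains open: a plain hydrogen, a cyclobutyl ring or a longer chain such as n-butyl could fall near compound 1, near compound 4 or elsewhere. This exchange is also seen as a single pair on one core, so whether it would give a step of similar size and direction on a different core cannot be said.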